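This account rests on a few compounds, and the source may have more. Where it says the series, first, only, none or still open, it means among the compounds named here.

Compound 2 `C=CCOc1ccccc1-c1ncc(C(=O)O)c(=O)[nH]1` was examined in a functional assay on the whole organism (strain Sprague-Dawley) for inhibition, with Rattus norvegicus as the target, with a stated time of 10 min (on this read-out lower numbers stand for an effect already at smaller amounts and higher numbers for an effect only at larger amounts of compound), where compound 2 gives 0.5 mg/kg. Compound 1 `CCC(C)Oc1ccccc1-c1ncc(C(=O)O)c(=O)[nH]1` gives 0.5 mg/kg in the same test, and no change at the digits printed from compound 1 to compound 2 (within the scatter). Compound 3 `CSc1ccccc1-c1ncc(C(=O)O)c(=O)[nH]1` reaches only a limit of the assay, > 20 mg/kg, as recorded at the limit of > 20 mg/kg in this assay, at which 1 of the 3 values shown sits. Accordingly, an at least 40-fold higher number from compound 2 to compound 3 (1.60 log units; beyond the scatter). The unmeasured compound 4 `C=CCOc1ccccc1-c1ncc(C(=O)OCC)c(=O)[nH]1` differs from compound 2 in a single place: ethyl in place of hydrogen on an oxygen next to a carbonyl group. Among the measured compounds shown here, none of the measured steps touches this group; each of them concerns the substituent on the aromatic ring, so they offer no direct guide to the direction of this change. The estimated step is a 1.4-fold higher number from compound 2 to compound 4 (0.15 log units; within the scatter), which is small. For compound 4 the expected value in this assay is 0.7 mg/kg, within a range from 0.25 mg/kg to 3 mg/kg.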

Compound 4, dose for 50% inhibition: 0.5 mg/kg
Compound 4: the middle estimate sits 1.4-fold (0.15 log units) above what was measured; the range from low to high includes it.
By their numbers in this assay, from the lowest: compounds 1, 2 and 4 (each within the scatter of the next). At a limit, above all of these: compound 3.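

Among the compounds shown here, until now only the substituent on the aromatic ring had varied, so this is the first view of the carboxy group, and in this assay there is no change at the digits printed from compound 2 to compound 4 (within the scatter) with ethoxycarbonyl in its place. In this pair, then, the whole-animal result does not depend on the hydrogen of the carboxy group. Nothing in the data shown accounts for this outcome.

As far as these compounds go, whether an amide or a longer chain on this oxygen would give the same result stays open. So does whether the ethyl group behaves alike with sec-butoxy on the aromatic ring.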